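The source may report more compounds than this note shows. Statements on the series, on what has been measured and on what is new or still open speak of the compounds shown alone.

In an ADME assay on Caco-2 cells (Homo sapiens) for permeability, in the apical to basolateral direction, with a stated time of 90 min, tested at 10 uM (on this read-out higher numbers stand for higher permeability and lower numbers for lower permeability), compound 1 `O=C(NC[C@@H]1[C@H]2CN(C(=O)OCc3cc(Cl)cc(Cl)c3)C[C@@H]12)c1ccc2[nH]c(=O)oc2c1` gives 137 10^-6 cm/s and compound 2 `O=C(NC[C@@H]1[C@H]2CN(C(=O)/C=C/c3cc(Cl)cc(Cl)c3)C[C@@H]12)c1ccc2[nH]c(=O)oc2c1` gives 38 10^-6 cm/s, the lower of these two numbers. Compound 3 `O=C(NC[C@@H]1[C@H]2CN(C(=O)CCc3cc(Cl)cc(Cl)c3)C[C@@H]12)c1ccc2[nH]c(=O)oc2c1` differs from compound 2 in one place, on a carbonyl carbon: 2-(3,5-dichlorophenyl)ethyl stands in place of 2-(3,5-dichlorophenyl)ethenyl (2-(3,5-dichlorophenyl)ethyl in place of 2-(3,5-dichlorophenyl)ethenyl on a carbonyl carbon). For the measured compounds named here, the only measured step at this carbonyl carbon is a 3.6-fold lower number from compound 1 to compound 2 (0.56 log units; beyond the scatter), which is modest but beyond the scatter. That single step is a thin guide, and the new change removes only the double bond outside the aromatic ring. The expected result is a small rise that stays within the scatter, a 1.4-fold higher number from compound 2 to compound 3 (0.16 log units; within the scatter). The estimate for compound 3 is 55 10^-6 cm/s, with an expected range of 25 10^-6 cm/s to 120 10^-6 cm/s.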

Compound 3, apparent permeability: 18 10^-6 cm/s
The estimate for compound 3 lay 3.1-fold (0.49 log units) above the measured number; the measured number lies below the stated range.
By their numbers in this assay, from the lowest: compound 3; then compound 2; then compound 1.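

In this assay taking away the double bond outside the aromatic ring brings no recovery but a 2.1-fold lower number from compound 2 to compound 3 (0.32 log units; beyond the scatter) on top of the earlier drop. Putting 2-(3,5-dichlorophenyl)ethyl in place of (3,5-dichlorobenzyl)oxy gives a 7.6-fold lower number from compound 1 to compound 3 (0.88 log units; beyond the scatter) as the largest step seen here. The number at this carbonyl carbon therefore depends on more than that one double bond.

Still open, as far as these compounds go, is how an amine, a carboxylic acid or a longer chain at this carbonyl carbon would read in this assay by comparison. Nothing available accounts for these differences.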